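Swapping Chloro for Trifluoromethyl on the Benzyl Ring

The source may report more compounds than this note shows. Statements on the series, on what has been measured and on what is new or still open speak of the compounds shown alone.

Going by the values given here, compound 2 `Clc1ccccc1Cn1nnc2c(NC3CC3)nc(-c3ccccc3)nc21` is one of two compounds measured so far in an assay on isolated protein for binding affinity to adenosine receptor A1 (Bos taurus) (a lower number here means a stronger inhibitor, a higher number a weaker inhibitor), and in that assay compound 2 gives 11000000 nM. The other is compound 1 `Fc1ccccc1Cn1nnc2c(NC3CC3)nc(-c3ccccc3)nc21`, which in this assay gives 15000000 nM. Among the compounds with values here, the single step seen so far, a 1.4-fold lower number from compound 1 to compound 2 (0.13 log units; within the scatter), stays within the scatter, so neither compound can be said to bind more strongly than the other; both are very weak binders. Compound 3 `FC(F)(F)c1ccccc1Cn1nnc2c(NC3CC3)nc(-c3ccccc3)nc21` differs from compound 2 in one place: trifluoromethyl in place of chloro on an aromatic carbon. Within the data shown here, the only measured step that bears on this change is a 1.4-fold lower number from compound 1 to compound 2 (0.13 log units; within the scatter), and it was too small to rise above the scatter. Compound 3 is therefore expected to show 10000000 nM in this assay, with a likely range from 3000000 nM to 40000000 nM. The step of a 1.1-fold lower number from compound 2 to compound 3 (0.04 log units; within the scatter) that this estimate implies is expected to remain within the scatter.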

Compound 3, inhibition constant: 7800000 nM
Estimate against measurement, compound 3: 1.3-fold (0.11 log units) above; the range from low to high includes it.
By their numbers in this assay, from the lowest: compounds 3, 2 and 1 (each within the scatter of the next).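

Placing trifluoromethyl, with 4 heavy atoms, where chloro has 1 heavy atom gives in this assay a 1.4-fold lower number from compound 2 to compound 3 (0.15 log units; within the scatter) and so adds a clearly bigger group to the comparison without producing a readable change. The step across the other new pair, a 1.9-fold lower number from compound 1 to compound 3 (0.28 log units; within the scatter), also stays within the scatter, so fluoro, chloro and trifluoromethyl on this aromatic carbon cannot be told apart in this assay, and all three compounds remain very weak binders. No outside information is available to explain this flat result.

On these data alone, it remains open whether an amine, a hydroxyl group or a carboxylic acid on this aromatic carbon would give a step beyond the scatter. As far as these compounds go, it is also open whether changes to the shared core, which stays the same in all three compounds, would give stronger binding.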